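The compounds below may be only part of what the source reports. "The series", "measured", "known", "first", "only" and "open" are said of these compounds alone.

The measured compounds:
Compound 1 `O=C(Nc1ccc(F)cc1)N1CCN(S(=O)(=O)c2sccc2-c2ccccc2Oc2ccc(O)c(O)c2)CC1`: in a functional assay on HeLa cells (Homo sapiens) for inhibition, read by CCK-8 assay, with a stated time of 48 h (a lower number here means a stronger inhibitor, a higher number a weaker inhibitor), compound 1 gives 14800 nM.
Compound 2 `COc1ccc(Oc2ccccc2-c2ccsc2S(=O)(=O)N2CCN(C(=O)Nc3ccc(F)cc3)CC2)cc1OC`: in this assay compound 2 gives > 20000 nM, which is a limit of the assay and not a number.

Compound 1 stands with the only number shown. The other value shown is the limit of > 20000 nM in this assay, at which 1 of the 2 values shown sits. Among the compounds with values here, the one measured step, an at least 1.3-fold higher number from compound 1 to compound 2 (0.13 log units; that floor lies within the scatter), concerns a group on an oxygen on an aromatic ring and sits at a floor within the scatter. Compound 3 `O=S(=O)(c1sccc1-c1ccccc1Oc1ccc(O)c(O)c1)N1CCN(C(=S)Nc2ccc(Cl)cc2)CC1` differs from compound 1 at another place: a group of 10 heavy atoms (7 carbon, 1 nitrogen, 1 sulfur, 1 chlorine; one six-membered aromatic ring of carbon only) in place of a group of 10 heavy atoms (7 carbon, 1 nitrogen, 1 oxygen, 1 fluorine; one six-membered aromatic ring of carbon only), on an amine nitrogen in a ring. Within the data shown here, no measured step touches this amine nitrogen in a ring, so the measured step gives no guidance on this change, and no step beyond the scatter is expected in this assay in either direction. For compound 3 the expected value in this assay is 15000 nM, with a range from 5000 nM to 40000 nM. The estimated step, a 1.0-fold higher number from compound 1 to compound 3 (0.01 log units; within the scatter), is expected to stay within the scatter.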

Compound 3, half-maximal inhibitory concentration: > 50000 nM
Compound 3 ended at the assay's limit (the forecaster's own chance of this, stated with the estimate: 40%); middle value at least 3.3-fold (0.52 log units) from the limit.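

Within the data shown here, the group on the amine nitrogen in a ring matters in this assay: the change gives an at least 3.3-fold higher number from compound 1 to compound 3 (0.52 log units; beyond the scatter), the first step here to lie beyond the scatter, whereas the earlier step, made at another place, has a floor within it. Going by these compounds, compound 3 stands at a limit of the assay and not at a number, and the full size of the step stays unknown: the limit of > 50000 nM in this assay, at which 1 of the 3 values shown sits. The entering group holds sulfur and chlorine in place of oxygen and fluorine, so this one step carries two differences at once.

The compounds shown leave open which of these two differences goes with the step. They also do not tell how a group such as an acetyl or a longer chain would fare on this amine nitrogen in a ring.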